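Chloro-fluoro phenyl change carried onto a second core

The compounds below may be only part of what the source reports. "The series", "measured", "known", "first", "only" and "open" are said of these compounds alone.

Compound 2 `CC/C(=C(/c1ccc(/C=C/C(=O)O)cc1)c1ccc2c(cnn2C)c1)c1ccccc1` and compound 1 `CC/C(=C(/c1ccc(/C=C/C(=O)O)cc1)c1ccc2c(cnn2C)c1)c1ccc(F)cc1Cl` share one core. In a functional assay on MCF7 cells (Homo sapiens) for antiproliferative activity, read by CellTiter-Glo, with a stated time of 5 days (on this read-out higher numbers stand for weaker inhibition and lower numbers for stronger inhibition), compound 2 gives 300 nM, and compound 1 gives 81 nM. The change between them is 2-chloro-4-fluorophenyl in place of phenyl on a double-bonded chain carbon bound to a double-bonded chain carbon and a saturated chain carbon, and it made a 3.7-fold lower number from compound 2 to compound 1 (0.57 log units; beyond the scatter). Compound 3 `O=C(O)/C=C/c1ccc(/C(=C(\c2ccccc2)C2CCC2)c2ccc3scnc3c2)cc1` rests on a different core; the difference between the two cores is not broken down here. In this assay compound 3 gives 16 nM, the lowest number of the three measured. Compound 4 `O=C(O)/C=C/c1ccc(/C(=C(\c2ccc(F)cc2Cl)C2CCC2)c2ccc3scnc3c2)cc1` is not yet measured and differs from compound 3 by 2-chloro-4-fluorophenyl in place of phenyl on a double-bonded chain carbon bound to a double-bonded chain carbon and a saturated ring carbon. This is the same kind of change as between compound 2 and compound 1, though there the place was a saturated chain carbon and here it is a saturated ring carbon. Compound 4 is expected to give a 3.2-fold lower number from compound 3 to compound 4 (0.51 log units; beyond the scatter), resting on a 3.7-fold lower number from compound 2 to compound 1 (0.57 log units; beyond the scatter). Compound 4 is therefore estimated at 5 nM, between 2 nM and 15 nM.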

Compound 4, half-maximal inhibitory concentration: 3 nM
The estimate for compound 4 lay 1.7-fold (0.22 log units) above the measured number, within the range that was stated.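

In this assay the 2-chloro-4-fluorophenyl change gave a 5.3-fold lower number from compound 3 to compound 4 (0.73 log units; beyond the scatter), so the lower number seen on the core of compound 1 recurs on the core of compound 3. The step carried over from one core to the other at a matching size: the same change on two cores in this assay, a 3.7-fold lower number (0.57 log units; beyond the scatter) from compound 2 to compound 1 and a 5.3-fold lower number (0.73 log units; beyond the scatter) from compound 3 to compound 4, 1.4-fold (0.16 log units) apart, within the scatter of two such steps. This rests on two pairs in one assay, and it shows neither why the change lowers the number nor whether it would do so on a third core.

As far as these compounds go, whether a phenyl carrying chlorine alone or fluorine alone would give a similar step remains open. Also open, from the compounds shown here alone, is how the step would behave with an amide in place of the carboxylic acid.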